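Methyl for hydrogen on a chain carbon: outlook for compound 4

A few compounds are considered here, and "the series" means these few. Any claim that something is new, unique, unknown or untested is made for them only; others in the source may bear on it.

Three compounds have numbers in a functional assay on the whole organism (Abdomen) with Mus musculus as the target; on this read-out higher numbers stand for an effect only at larger amounts of compound and lower numbers for an effect already at smaller amounts. Compound 1 `CC(C)c1nc(Cc2c[nH]cn2)c(C(C)C)s1` gives 23.8 mg/kg. Compound 2 `CCc1nc(Cc2c[nH]cn2)c(C(C)C)s1` gives 25.3 mg/kg in this assay. Compound 3 `Cc1nc(C)c(Cc2c[nH]cn2)s1` gives 1 mg/kg, the lowest of the three; the difference between its core and the core of compound 2 is not broken down here.

Within the data shown here, the only change with a measured step is methyl in place of hydrogen on a saturated chain carbon bound to an aromatic carbon and a saturated chain carbon. It produced a 1.1-fold lower number from compound 2 to compound 1 (0.03 log units; within the scatter).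

Compound 4 `Cc1nc(C)c(C(C)c2c[nH]cn2)s1` is not yet measured in this assay. It differs from compound 3 by methyl in place of hydrogen on a saturated chain carbon bound to two aromatic carbons. The place is not the same word for word: in the earlier pair the carbon is bound to an aromatic carbon and a saturated chain carbon, here to two aromatic carbons, so this is the same kind of change rather than the same one. The change occurs twice among the compounds shown.

Because the earlier step of a 1.1-fold lower number from compound 2 to compound 1 (0.03 log units; within the scatter) stayed within the scatter, the step expected here is a 1.2-fold higher number from compound 3 to compound 4 (0.08 log units; within the scatter). The expectation rests on compound 3 and its value of 1 mg/kg being carried over. For compound 4 the number in this assay is estimated at 1.2 mg/kg, with 0.4 mg/kg to 4 mg/kg as the expected range.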

Compound 4, dose for half-maximal effect: > 30 mg/kg
Compound 4: only a limit was reported; the forecaster's own chance of this, stated with the estimate: 5%; middle value at least 25-fold (1.39 log units) from the limit.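

In this assay, methyl in place of hydrogen on a saturated chain carbon bound to two aromatic carbons gave an at least 30-fold higher number from compound 3 to compound 4 (1.47 log units; beyond the scatter). On these data alone, compound 4 stands at > 30 mg/kg, which is a limit of the assay and not a number, so the full size of that step stays unknown. The change therefore does not carry over from one core to the other as a fixed step, although two pairs give no rule for further cores and no cause for the gap: the same change on two cores in this assay, a 1.1-fold lower number (0.03 log units; within the scatter) from compound 2 to compound 1 and an at least 30-fold higher number (1.47 log units; beyond the scatter) from compound 3 to compound 4, at least 31-fold (1.50 log units) apart, beyond the scatter of two such steps

Still open is whether the gap follows the place of the change, a carbon bound to two aromatic carbons rather than to an aromatic carbon and a saturated chain carbon, or the core that carries it, since the two differ together in the pairs shown. Also open, as far as these compounds go, is how a hydroxyl group or a fluorine atom in place of the methyl on that carbon of compound 4 would read in this assay.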